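Aryl substituent series: methyl to tert-butyl

The compounds below may be only part of what the source reports. "The series", "measured", "known", "first", "only" and "open" are said of these compounds alone.

Of the compounds shown here, three sharing one core have been measured in an assay on isolated protein for inhibition of Dihydrofolate reductase (Homo sapiens), read by spectrophotometry, using NADPH, with stated times of 5 s and 6 min; a higher number here means a weaker inhibitor, a lower number a stronger inhibitor. Compound 1 `COc1ccc(OCCCON2C(N)=NC(N)=NC23CCOCC3)cc1` gives 11.1 nM. Compound 2 `NC1=NC2(CCOCC2)N(OCCCOc2ccc(Cl)cc2)C(N)=N1` gives 33.6 nM, and compound 3 `Cc1ccc(OCCCON2C(N)=NC(N)=NC23CCOCC3)cc1` gives 56.8 nM. For the measured compounds named here, compound 3 carries the highest of the three numbers, but only the step of a 5.1-fold higher number from compound 1 to compound 3 (0.71 log units; beyond the scatter) lies beyond the scatter; the step of a 1.7-fold higher number from compound 2 to compound 3 (0.23 log units; within the scatter) does not, so compounds 2 and 3 cannot be told apart on these data. The step of a 3.0-fold higher number from compound 1 to compound 2 (0.48 log units; beyond the scatter) is modest.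

Compound 4 `CC(C)(C)c1ccc(OCCCON2C(N)=NC(N)=NC23CCOCC3)cc1` differs from compound 3 by tert-butyl in place of methyl on an aromatic carbon. Going by the values given here, no measured step exchanges one alkyl group for another at the same aromatic carbon. The steps of a 5.1-fold higher number from compound 1 to compound 3 (0.71 log units; beyond the scatter) and a 1.7-fold higher number from compound 2 to compound 3 (0.23 log units; within the scatter) bear on it only indirectly: they show that exchanging the group at that carbon moves the number in this assay by modest amounts, and that methyl has so far given the highest number. A change of the same modest size is therefore expected, with a further rise judged somewhat more likely than a fall, though a result within the scatter of compound 3 would not be surprising. Compound 4 is expected to give 90 nM, in a range from 35 nM to 250 nM, which means an estimated step of a 1.6-fold higher number from compound 3 to compound 4 (0.20 log units; within the scatter).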

Compound 4, half-maximal inhibitory concentration: 3.72 nM
For compound 4 the middle estimate is 24-fold (1.38 log units) above the measured one; measured number below the stated range.
By their numbers in this assay, from the lowest: compound 4; then compound 1; then compounds 2 and 3 (each within the scatter of the next).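

At this aromatic carbon in this assay, tert-butyl gives the lowest number of the series, with a 15-fold lower number from compound 3 to compound 4 (1.18 log units; beyond the scatter), a 9.0-fold lower number from compound 2 to compound 4 (0.96 log units; beyond the scatter) and a 3.0-fold lower number from compound 1 to compound 4 (0.47 log units; beyond the scatter), so compound 4 is the strongest inhibitor of the four and methoxy no longer holds that place. The position is therefore more sensitive to exchange than the earlier modest steps suggested, and the two alkyl groups, methyl with its single carbon and tert-butyl with its four, give the widest gap seen here, so the presence of an alkyl group at this carbon does not by itself set the number. Nothing available on these compounds accounts for the gap between the two alkyl groups.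

For the compounds shown here, with only two alkyl groups in hand, it remains open whether ethyl or isopropyl would fall between compound 3 and compound 4, or whether the number changes abruptly somewhere along that sequence. Also open, going by these compounds, is how this carbon responds to a cyclohexyl ring, a phenyl ring, an amine or a carboxylic acid, and whether the gain from tert-butyl holds with a longer chain in place of the shared linker.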